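Hydroxy for chloro on a weakly active hydrazone

The source may report more compounds than this note shows. Statements on the series, on what has been measured and on what is new or still open speak of the compounds shown alone.

The account follows a series built on a shared thiosemicarbazide core. For compound 1 `C/C(=N\NC(=S)N1CCNCC1)c1ccc(Cl)cc1` the result in a functional assay on HL-60 cells (Homo sapiens) for antiproliferative activity, with a stated time of 48 h (a higher number here means a weaker inhibitor, a lower number a stronger inhibitor), reads "not determined" (no result reported), so no number places it. Among the compounds with values here, the only measured relative is compound 2 `C/C(=N\NC(=S)N1CCNCC1)c1cccc([N+](=O)[O-])c1`, which carries a nitro group in place of the chloro of compound 1; in this assay compound 2 gives 62000 nM, a weak inhibition. Compound 3 `C/C(=N\NC(=S)N1CCNCC1)c1ccc(O)cc1` differs from compound 1 by hydroxy in place of chloro on an aromatic carbon. Within the data shown here, with no measured pair to lean on, the size and direction of the step from compound 1 to compound 3 in this assay cannot be read from data; a step within the usual scatter is as plausible as one beyond it. Resting on the weak value of compound 2 alone, compound 3 is expected to inhibit weakly as well, with an estimated half-maximal inhibitory concentration of 50000 nM, ranging from 10000 nM to 300000 nM.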

Compound 3, half-maximal inhibitory concentration: 60000 nM
Beside the measured number, compound 3's estimate is 1.2-fold (0.08 log units) below it; measured number inside the range.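

In this assay, within the data shown here, compound 1 reads "not determined" (no result reported), so no step from compound 1 to compound 3 can be read. The compounds shown leave open what hydroxy in place of chloro does to this activity. Nothing given here bears on the value of compound 3.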